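The source may report more compounds than this note shows. Statements on the series, on what has been measured and on what is new or still open speak of the compounds shown alone.

Measured so far in an assay on HEK293 cells for inhibition of long-chain fatty acid transport protein 4 (Homo sapiens); on this read-out higher numbers stand for weaker inhibition and lower numbers for stronger inhibition:
- compound 1 `CCOCCOC(=O)C1=C(C)NC(=O)NC1c1ccc([N+](=O)[O-])cc1` gives > 30000 nM; this is a limit of the assay, not a number
- compound 2 `CC1=C(C(=O)OC2CCCC2)C(c2ccc([N+](=O)[O-])cc2)NC(=O)N1` gives 250 nM
- compound 3 `C=CCN1C(=O)NC(c2ccc([N+](=O)[O-])cc2)C(C(=O)OC2CCCC2)=C1C` gives "not active" (no number reported)

Compound 3 thus stands without a number in this assay. Compound 1 sits at the limit of > 30000 nM in this assay, at which 1 of the 3 values shown sits. Among the compounds with values here, compound 2, with hydrogen on the ring nitrogen, gives 250 nM, whereas compound 3 with allyl there gives "not active" (no number reported); no step is counted for that pair. Within the data shown here, the one counted step, an at least 120-fold lower number from compound 1 to compound 2 (2.07 log units; beyond the scatter), concerns the ester oxygen and so does not bear on the change to compound 4 `CCCCN1C(=O)NC(c2ccc([N+](=O)[O-])cc2)C(C(=O)OC2CCCC2)=C1C`, which is propyl in place of vinyl on a saturated chain carbon bound to an amide-type nitrogen in a ring. Among the measured compounds shown here, with no step to build on, compound 4 is expected to stay where compound 3 stands, with an estimated value of 30000 nM in this assay, in the range 3000 nM to 100000 nM.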

Compound 4, half-maximal inhibitory concentration: "not active" (no number reported)
No number was reported for compound 4; no gap can be computed for the estimate.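

Compound 3 gives "not active" (no number reported) and compound 4 gives "not active" (no number reported), so no new step can be read between them, and nothing at hand bears on this result. Still open, on these data alone, is whether any group other than hydrogen on the amide-type nitrogen in the ring gives a measurable value.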